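Trifluoromethyl for chloro on a quinolinone amide series

The source may hold more compounds than are shown below. What is called first, only, known or untested is meant among the compounds shown, and "the series" means these compounds.

Compound 1 `O=C(Nc1ccc(Cl)cc1)c1cc(=O)[nH]c2cc(Br)ccc12` carries chloro on its aniline ring; in a functional assay on KYSE-70 cells for antiproliferative activity against KYSE-70 cell line (Homo sapiens), read by MTT assay, with a stated time of 72 h (a higher number here means a weaker inhibitor, a lower number a stronger inhibitor), compound 1 gives only a limit of > 20000 nM. Compound 2 `O=C(Nc1ccc(C(F)(F)F)cc1)c1cc(=O)[nH]c2cc(Br)ccc12` likewise gives a limit, > 20000 nM. The step that the two limits leave unreadable from compound 1 to compound 2, change (trifluoromethyl in place of chloro on an aromatic carbon), cannot be sized because the limit of > 20000 nM in this assay, at which 2 of the 3 values shown sit, covers both values. Compound 3 `O=C(Nc1cc(F)cc(F)c1)c1cc(=O)[nH]c2cc(Cl)ccc12` is the one numbered entry: in this assay compound 3 gives 9000 nM. How the core of compound 3 differs from that of compound 1 is not broken down here. Compound 4 `O=C(Nc1cc(F)cc(F)c1)c1cc(=O)[nH]c2cc(C(F)(F)F)ccc12` arises by trifluoromethyl in place of chloro on an aromatic carbon; its place is meta to a fused ring and para to a fused ring, whereas in compound 2 it sat para to a large group, so this is the same kind of change, not the same. With the earlier step unreadable, compound 4 is expected to move by a 1.3-fold higher number from compound 3 to compound 4 (0.12 log units; within the scatter) in this assay, resting only on compound 3 at 9000 nM. Compound 4 is estimated at 12000 nM, between 4000 nM and 30000 nM.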

Compound 4, half-maximal inhibitory concentration: 14200 nM
Compound 4: middle estimate off by 1.2-fold (0.07 log units), on the low side; low and high end bracket the measured number.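

In this assay, trifluoromethyl in place of chloro on the core shared by compound 3 and compound 4 gives a 1.6-fold higher number from compound 3 to compound 4 (0.20 log units; within the scatter), so on this core the two groups are not told apart. The same kind of change on the aniline ring, in compound 1 and compound 2, cannot be read, since both values are limits: the limit of > 20000 nM in this assay, at which 2 of the 4 values shown sit. This leaves a single readable step on a single core, which does not show whether the result carries from one core to another.

Open, on these data alone, is whether an amine or a carboxylic acid at the place held by chloro in compound 3 would stand apart from these values. Also open, as far as these compounds go, is how the same change behaves on a core where the values are not limits.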